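Swapping a Fused Ring for a Branched Amine

The source may hold more compounds than are shown below. What is called first, only, known or untested is meant among the compounds shown, and "the series" means these compounds.

Measured compounds:
compound 1, `CS(=O)(=O)c1ccc(C(=O)N2CCC(C(=O)N3CCc4ccccc43)CC2)cc1[N+](=O)[O-]`: > 60000 nM
compound 2, `Cc1ccc(N2CCN(C(=O)CCCNC(=O)c3ccc(S(C)(=O)=O)c([N+](=O)[O-])c3)CC2)cc1`: > 60000 nM

In an assay on isolated protein for inhibition of vitamin D3 receptor (Homo sapiens), read by fluorescence polarization (a higher number here means a weaker inhibitor, a lower number a stronger inhibitor), compound 1 gives > 60000 nM, which is a limit of the assay and not a number. Compound 2 likewise reaches only a limit, > 60000 nM. The two measured results therefore share one feature: the limit of > 60000 nM in this assay, at which 2 of the 2 values shown sit. Because of the limit of > 60000 nM in this assay, at which 2 of the 2 values shown sit, compound 1 stands at the edge of what this assay can report, with no measurable inhibition.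

Compound 3, `CC(C)N(C(=O)C1CCN(C(=O)c2ccc(S(C)(=O)=O)c([N+](=O)[O-])c2)CC1)C(C)C`, differs from compound 1 in a single spot: diisopropylamino in place of 2,3-dihydro-1H-indol-1-yl on a carbonyl carbon. For the measured compounds named here, no measured pair of compounds differs in one place, so there is no measured step from which the size of this change can be read.

The expectation rests on compound 1 alone, whose value > 60000 nM is a limit, and the change from compound 1 to compound 3 is expected to leave the result at a limit, with the step of a number no higher from compound 1 to compound 3 (the limit leaves the size open) estimated as none beyond the scatter. Compound 3 is thus estimated at 60000 nM, within a range from 25000 nM to 200000 nM.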

Compound 3, half-maximal inhibitory concentration: > 60000 nM
Compound 3 was reported as a limit; the forecaster's own chance of this, stated with the estimate: 85%; the middle value sits exactly at the limit.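

In this assay compound 3 gives > 60000 nM as a limit and not a number. No size can be read for the change from compound 1 to compound 3 because of what all the results shown share: the limit of > 60000 nM in this assay, at which 3 of the 3 values shown sit.

Left open is whether any change to the shared core gives a measurable value in this assay at all.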